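Permeability notes on compounds 1 to 4

The source may report more compounds than this note shows. Statements on the series, on what has been measured and on what is new or still open speak of the compounds shown alone.

Measured so far:
compound 1 `N#Cc1c(Cl)nc(NCCC2CCN(Cc3ccccc3)CC2)c(C#N)c1-c1ccccc1` gives "not determined" (no result reported) in an ADME assay for permeability, using PAMPA, with a stated time of 4 h, tested at 1 mg/mL; a lower number here means that the compound crosses the layer more slowly, a higher number that the compound crosses the layer faster
compound 2 `N#Cc1c(NCCC2CCN(Cc3ccccc3)CC2)nc(NCCC2CCN(Cc3ccccc3)CC2)c(C#N)c1-c1ccccc1` gives "not determined" (no result reported) in this assay
compound 3 `N#Cc1c(Cl)nc(NCCCC2CCN(Cc3ccccc3)CC2)c(C#N)c1-c1ccccc1` gives 10.1 10^-6 cm/s in this assay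

Going by the values given here, compound 3 therefore stands as the only entry with a number in this assay; compounds 1 and 2 carry no result, so no step between measured compounds can be drawn and nothing is known about how a change in the chain or at the chloro position moves the read-out.

Compound 4 `N#Cc1cc(C#N)c(NCCCC2CCN(Cc3ccccc3)CC2)nc1Cl` has not yet been measured. It differs from compound 3 by hydrogen in place of phenyl on an aromatic carbon of the shared core. Without a measured step to lean on, the expectation for this assay is a modest downward move, of a size that may or may not clear the usual scatter. Compound 4 is expected to give 6 10^-6 cm/s, with a range from 3 10^-6 cm/s to 12 10^-6 cm/s. The step this estimate implies, from compound 3 to compound 4, is expected to be a 1.7-fold lower number from compound 3 to compound 4 (0.23 log units; within the scatter).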

Compound 4, apparent permeability: 5.98 10^-6 cm/s
Estimate against measurement, compound 4: 1.0-fold (0.00 log units) above, and the stated range covers the measured number.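

At the aromatic carbon opposite the ring nitrogen, ortho to two cyano groups, the series now has its first readable step: in this assay hydrogen in place of phenyl gives a 1.7-fold lower number from compound 3 to compound 4 (0.23 log units; within the scatter) for this core and chain. Even with a whole phenyl group of six heavy atoms gone from this carbon, this assay does not tell the two compounds apart. Nothing measured here gives a reason for this result.

Steps involving compound 1 or compound 2 cannot be read, so the chain and the chloro position still have no measured step. On these data alone, it remains open whether another group on this carbon, such as an amine, a carboxylic acid or a methyl group, would give a step beyond the scatter.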